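Pyrimidin-2-yl in place of pyridin-2-yl in compound 3

This account rests on a few compounds, and the source may have more. Where it says the series, first, only, none or still open, it means among the compounds named here.

Measured in a functional assay on MGC-803 cells (Homo sapiens) for inhibition, read by MTT assay, with a stated time of 72 h; a lower number here means a stronger inhibitor, a higher number a weaker inhibitor:
- compound 1 `FC(F)(F)c1ccc(CSc2nc(N3CCN(c4ccccc4)CC3)cc(C(F)(F)F)n2)cc1` gives 35200 nM
- compound 2 `FC(F)(F)c1ccc(CSc2nc(N3CCN(c4ccccn4)CC3)cc(C(F)(F)F)n2)cc1` gives 23500 nM

Only these two numbers exist so far. Compound 2 holds the lower one, but it stands within the usual scatter of compound 1, so the pair cannot truly be ranked. Compound 3 `FC(F)(F)c1ccc(CSc2nc(N3CCN(c4ncccn4)CC3)cc(C(F)(F)F)n2)cc1` keeps the shared core of compound 2 and changes one group pyrimidin-2-yl in place of pyridin-2-yl on an amine nitrogen in a ring. Among the compounds with values here, only one measured step bears on this place, the swap of phenyl for pyridin-2-yl, and it was small (a 1.5-fold lower number from compound 1 to compound 2 (0.18 log units; within the scatter)). One small step is thin evidence, but it gives no reason to predict a real shift in either direction. The expected change in this assay therefore stays within the scatter (a 1.0-fold lower number from compound 2 to compound 3 (0.01 log units; within the scatter)). Compound 3 is estimated at 23000 nM (expected range 10000 nM to 50000 nM).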

Compound 3, half-maximal inhibitory concentration: 35200 nM
For compound 3 the middle estimate is 1.5-fold (0.18 log units) below the measured one; the measured number falls inside the stated range.
By their numbers in this assay, from the lowest: compounds 2, 1 and 3 (each within the scatter of the next).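

In this assay the swap of pyridin-2-yl for pyrimidin-2-yl on the amine nitrogen in the ring gives a 1.5-fold higher number from compound 2 to compound 3 (0.18 log units; within the scatter) and the swap of phenyl for pyrimidin-2-yl gives no change at the digits printed from compound 1 to compound 3 (within the scatter) as well. This position has now carried phenyl, a ring with 1 hetero atom and a ring with 2 hetero atoms, and no step among these three compounds leaves the scatter, so the added ring nitrogen does not separate them in this assay. No measurement shown here accounts for these small steps. Still open, as far as these compounds go, is whether a group of a different kind on that same nitrogen, such as a benzyl group, an acetyl group or a short chain ending in a carboxylic acid, would give a real step. Also open, from the compounds shown here alone, is whether any group at this position could bring a real step on the shared core.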